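The compounds below may be only part of what the source reports. "The series", "measured", "known", "first", "only" and "open" are said of these compounds alone.

Compound 1 `N#Cc1c(-c2cccc([N+](=O)[O-])c2)c(C#N)c(=O)n(/N=C/c2cn(-c3ccccc3)nc2-c2ccccc2)c1N` and compound 2 `N#Cc1c(-c2ccc([N+](=O)[O-])cc2)c(C#N)c(=O)n(/N=C/c2cn(-c3ccccc3)nc2-c2ccccc2)c1N` share one core and differ only in the nitrophenyl group carried on it. In an ADME assay on HeLa cells (Homo sapiens) for cytotoxicity, read by MTT assay (a lower number here means a stronger inhibitor, a higher number a weaker inhibitor), compound 1 gives > 200 ug/mL, which is a limit of the assay rather than a number. In this assay compound 2 likewise gives > 200 ug/mL, again a limit and not a number. For that reason a step that the two limits leave unreadable from compound 1 to compound 2 cannot be sized, and the limit of > 200 ug/mL in this assay, at which 2 of the 2 values shown sit, shows that both values rest at the same limit. Compound 2 thus stands at the limit, with no numerical value to place it more closely. Compound 3 `N#Cc1c(-c2ccccc2Br)c(C#N)c(=O)n(/N=C/c2cn(-c3ccccc3)nc2-c2ccccc2)c1N` has not yet been measured; it differs from compound 2 by 2-bromophenyl in place of 4-nitrophenyl on an aromatic carbon. Among the compounds with values here, the only measured step concerns an exchange of the same aryl group, but its size is not readable, so the data give no direction for the change to compound 3. Compound 3 is therefore expected to stay at the limit as well, with an estimate of 200 ug/mL in a range from 100 ug/mL to 400 ug/mL. The expected step is then a number no higher from compound 2 to compound 3 (the limit leaves the size open).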

Compound 3, half-maximal inhibitory concentration: > 200 ug/mL
Compound 3: no number, only a limit; the forecaster's own chance of this, stated with the estimate: 80%; the middle value sits exactly at the limit.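

In this assay compound 3 gives > 200 ug/mL, a limit of the assay and not a number. The steps to compound 3 from compound 1 and compound 2 therefore cannot be read: the limit of > 200 ug/mL in this assay, at which 3 of the 3 values shown sit.

The compounds shown leave open whether exchanging the aryl group on the shared core changes the value in this assay at all.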